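Aryl swap on compound 1: lipophilicity note

A few compounds are considered here, and "the series" means these few. Any claim that something is new, unique, unknown or untested is made for them only; others in the source may bear on it.

compound 1 `CNC(=O)c1cc(C(=O)N[C@H]2CC[C@H](O)CC2)c([C@@H](C)c2ccc(Cl)cc2)o1` — 3.5
compound 2 `CNC(=O)c1cc(C(=O)N[C@H]2[C@@H]3COC[C@@H]32)c([C@@H](C)c2ccccc2)o1` — 4.1
compound 3 `CCC(=O)c1c[nH]c(C(=O)NC)c1` — 3.1

All three numbers come from a physicochemical assay for lipophilicity; a lower number here means a more polar compound, a higher number a more lipophilic compound. Compound 1 holds the second highest of the three: compound 3 lies lower, beyond the scatter, and compound 2 lies higher, also beyond the scatter. Compound 3 is the nearest to compound 1, compound 2 the furthest. Among the measured compounds shown here, no pair of measured compounds differs in a single place, so no measured step is available to calibrate the change that follows.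

Compound 4 `CNC(=O)c1cc(C(=O)N[C@H]2CC[C@H](O)CC2)c([C@@H](C)c2cccc(OC)c2)o1` has not yet been measured in this assay. Relative to compound 1 it carries 3-methoxyphenyl in place of 4-chlorophenyl on a saturated chain carbon bound to an aromatic carbon and a saturated chain carbon. A chlorine leaves and an oxygen-bearing group with one hydrogen-bond acceptor enters; the rest of the molecule is unchanged. On that change alone, compound 4 is expected to come out lower than compound 1 in this assay, with a step of a number 0.70 log units lower from compound 1 to compound 4 (beyond the scatter) expected, beyond the scatter. The estimate for compound 4 in this assay is 2.8, expected to fall within 2.3 to 3.3.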

Compound 4, distribution coefficient: 2.9
For compound 4 the middle estimate is 0.10 log units below the measured one; low and high end bracket the measured number.
By their numbers in this assay, from the lowest: compounds 4 and 3 (each within the scatter of the next); then compound 1; then compound 2.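

The swap of 4-chlorophenyl for 3-methoxyphenyl gives the series its first single-place step in this assay, with a number 0.60 log units lower from compound 1 to compound 4 (beyond the scatter) on an otherwise unchanged molecule. Among the compounds shown here, the number in this assay therefore responds to the aryl group on a saturated chain carbon bound to an aromatic carbon and a saturated chain carbon, which the earlier compounds, differing in several places at once, could not show. Nothing available accounts for the size or direction of this step.

Neither 3-chlorophenyl nor 4-methoxyphenyl has been measured on the core of compound 1. Still open, as far as these compounds go, is what step each of these groups would give on that core. Also open, from the compounds shown here alone, are the readings for other aryl groups, such as aminophenyl or a phenyl bearing a carboxylic acid, and whether the same swap gives a similar step on another core.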